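Turning one stereocentre in a slowly cleared compound

The source may report more compounds than this note shows. Statements on the series, on what has been measured and on what is new or still open speak of the compounds shown alone.

In an ADME assay (liver) for metabolic stability, with Liver microsome (Rattus norvegicus) as the target, using microsomes and NADPH, with a stated time of 30 min, at 37 degrees C, tested at 1 uM (a higher number here means faster removal of the compound, a lower number slower removal), compound 3 `C[C@](O)(CO)c1ccc(-c2ncc(S(=O)(=O)c3ccc(N)nc3)s2)c(Cl)c1` gives < 14 mL.min-1.g-1 as its result, which is a limit of the assay and not a number. Compound 1 `C[C@@](O)(c1ccc(-c2ncc(S(=O)(=O)c3ccc(N)nc3)s2)c(Cl)c1)C(F)(F)F` gives < 14 mL.min-1.g-1 as its result, also a limit. Compound 2 `Nc1ccc(S(=O)(=O)c2cnc(-c3ccc(S(N)(=O)=O)cc3Cl)s2)cn1` gives a true number of 107 mL.min-1.g-1 in the same test. One measured step is an at least 7.6-fold higher number from compound 1 to compound 2 (0.88 log units; beyond the scatter) on moving to the sulfamoyl group. Another is an at least 7.6-fold lower number from compound 2 to compound 3 (0.88 log units; beyond the scatter) on leaving that group. The remaining pair shows a step that the two limits leave unreadable from compound 1 to compound 3 in this small set. Compound 3 therefore stands at the limit of < 14 mL.min-1.g-1 in this assay, at which 2 of the 3 values shown sit, in this set.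

Compound 4 `C[C@@](O)(CO)c1ccc(-c2ncc(S(=O)(=O)c3ccc(N)nc3)s2)c(Cl)c1` keeps every group of compound 3, and the only difference is this: the two compounds have the same atoms and bonds and differ only in configuration as drawn: 1 of 1 stereo elements differ; a stereocentre at a saturated chain carbon is drawn R in compound 3 and S in compound 4 and nothing else. Among the compounds with values here, all the measured steps swap groups, and none changes configuration alone, so they offer only indirect guidance. With no group changed, and with compound 3 at the limit of < 14 mL.min-1.g-1 as its starting point, no step beyond the scatter is expected in this assay for this change. The expected step is a step that the limit leaves unreadable from compound 3 to compound 4 on this estimate. For compound 4 the estimated value is 12 mL.min-1.g-1 with an expected range from 6 mL.min-1.g-1 to 30 mL.min-1.g-1 in this test, and a reported limit would be no surprise.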

Compound 4, intrinsic clearance in microsomes: < 14 mL.min-1.g-1
Compound 4: only a limit was reported (the forecaster's own chance of this, stated with the estimate: 65%); the middle value lies beyond the limit too.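

Turning the stereocentre from R to S leaves compound 4 at the same limit as compound 3, so the steps linking compound 4 to compound 3 and to compound 1 cannot be read, and the limit now covers most of the set: the limit of < 14 mL.min-1.g-1 in this assay, at which 3 of the 4 values shown sit. The one readable new step is an at least 7.6-fold lower number from compound 2 to compound 4 (0.88 log units; beyond the scatter), on moving from sulfamoyl to 1-hydroxy-1-(hydroxymethyl)ethyl, and it matches the step already printed for compound 3, so slow removal in this assay holds for both drawn configurations of this group. This pair isolates the stereocentre from every other change, which no earlier pair could do, yet it can say only that neither form gave a readable number: the fact that compounds 3 and 4 differ only in the configuration as drawn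

As far as these compounds go, how far apart compound 3 and compound 4 truly lie stays open, as a limit hides any difference beneath it. Also open, from the compounds shown here alone, is whether an amine or a carboxylic acid in place of the hydroxymethyl group, or a longer chain at this carbon, would keep removal as slow and would make the configuration show up as a readable difference.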